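A few compounds are considered here, and "the series" means these few. Any claim that something is new, unique, unknown or untested is made for them only; others in the source may bear on it.

Among the measured compounds shown here, compound 1 `CCCCS(=O)(=O)Oc1ccc(/C=C/C(=O)Nc2ccccc2)cc1OC` stands lowest of the two numbers so far in a toxicity assay on L02 cells (Homo sapiens) for cytotoxicity, read by MTT assay, with a stated time of 24 h (a lower number here means that less compound is tolerated, a higher number that more compound is tolerated), where compound 1 gives 3320 nM. For the measured compounds named here, its only measured companion, compound 2 `CCCCS(=O)(=O)Oc1ccc(/C=C/C(=O)Nc2ccc(CC)cc2)cc1OC`, gives 89000 nM in this assay, and the single step between them, a 27-fold higher number from compound 1 to compound 2 (1.43 log units; beyond the scatter), came with ethyl in place of hydrogen on an aromatic carbon. Compound 3 `CCCCS(=O)(=O)Oc1ccc(/C=C/C(=O)Nc2ccccc2Br)cc1OC` differs from compound 1 by bromo in place of hydrogen on an aromatic carbon. Going by the values given here, the ethyl step touches the same aromatic ring of compound 1, but with a different group at a different place, so it bears on the present change only loosely, and it is the only guide available. A higher number than that of compound 1 is therefore expected for compound 3, but by a smaller margin than the ethyl step, so the step is estimated at a 3.0-fold higher number from compound 1 to compound 3 (0.48 log units; beyond the scatter). Compound 3 is expected to give about 10000 nM in this assay, within a range from 2500 nM to 40000 nM.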

Compound 3, half-maximal cytotoxic concentration: 5000 nM
The estimate for compound 3 lay 2.0-fold (0.30 log units) above the measured number, within the range that was stated.
By their numbers in this assay, from the lowest: compounds 1 and 3 (each within the scatter of the next); then compound 2.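

In this assay, bromo on an aromatic carbon ortho to a large group gives a step that stays within the scatter: a 1.5-fold higher number from compound 1 to compound 3 (0.18 log units; within the scatter). Putting a group on this ring therefore does not by itself move the number far, and the large shift so far belongs to the ethyl of compound 2 alone, as the step with 2-bromophenyl in place of 4-ethylphenyl also shows: an 18-fold lower number from compound 2 to compound 3 (1.25 log units; beyond the scatter). No measurement at hand bears on why these numbers fall as they do.

Going by these compounds, it remains open whether chloro, an amine or a carboxylic acid at this same place would also stay within the scatter of compound 1. On these data alone, it is also open whether bromo at the place held by the ethyl of compound 2 would bring a step as large as the ethyl did.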